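The source may report more compounds than this note shows. Statements on the series, on what has been measured and on what is new or still open speak of the compounds shown alone.

Measured compounds:
- compound 1, `C[C@H](CCCOc1ccccc1CN(C)C(=O)c1ccc(-c2ccco2)cc1)CC(=O)O`, in an ADME assay on the whole organism (strain CD-1) for pharmacokinetics, with Mus musculus as the target, at a dose of 3 mg/kg by the intravenous route (a higher number here means faster removal of the compound, a lower number slower removal), compound 1 gives 0.3 mL/min/kg
- compound 2, `CN(Cc1ccccc1OCCC[C@@H]1C[C@@H]1C(=O)O)C(=O)c1ccc(-c2ccco2)cc1`, in this assay compound 2 gives 1.7 mL/min/kg

Among the measured compounds shown here, compound 2 stands at the higher of the two numbers so far; the one measured step, a 5.7-fold higher number from compound 1 to compound 2 (0.75 log units; beyond the scatter), lies beyond the scatter and is the only reading in hand of how this acid-bearing side chain affects removal of the compound.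

Compound 3, `CC(CCOc1ccccc1CN(C)C(=O)c1ccc(-c2ccco2)cc1)CCC(=O)O`, has not yet been measured. It differs from compound 2 by 3-carboxy-1-methylpropyl in place of (2-carboxycyclopropyl)methyl on a saturated chain carbon, two bonds along the chain from an oxygen on an aromatic ring. The group that leaves carries the three-membered ring; the group that enters is an open chain with a methyl branch and the carboxylic acid at its end, closer in kind to the 1-(carboxymethyl)ethyl of compound 1 than to the 2-carboxycyclopropyl of compound 2.

For the measured compounds named here, the only step that bears on this change is a 5.7-fold higher number from compound 1 to compound 2 (0.75 log units; beyond the scatter), where the ring entered and the number rose. Going the other way, from ring back to open chain, a drop of roughly similar size is expected, with wide uncertainty since no compound with this exact chain has been measured. For compound 3 the expected step is a 2.8-fold lower number from compound 2 to compound 3 (0.45 log units; beyond the scatter), and the estimate is 0.6 mL/min/kg, within 0.2 mL/min/kg to 2 mL/min/kg.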

Compound 3, clearance: 4 mL/min/kg
Compound 3: the middle estimate sits 6.7-fold (0.82 log units) below what was measured, outside the stated range (above it).
By their numbers in this assay, from the lowest: compound 1; then compound 2; then compound 3.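

In this assay the open chain does not return the number towards that of compound 1, which stands at 0.3 mL/min/kg; replacing the ring in (2-carboxycyclopropyl)methyl with 3-carboxy-1-methylpropyl gives a 2.4-fold higher number from compound 2 to compound 3 (0.37 log units; beyond the scatter), so the three-membered ring is not what separates the higher numbers from the lowest one in this set. The comparison between the two open chains carries the larger message: 3-carboxy-1-methylpropyl in place of 2-(carboxymethyl)propyl gives a 13-fold higher number from compound 1 to compound 3 (1.12 log units; beyond the scatter), a large step for a change that involves no ring, so in these three compounds the low number belongs to the particular chain of compound 1 and not to open chains in general. Nothing available on these compounds accounts for either step.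

The compounds shown leave open whether the low number of compound 1 depends on its methyl branch, which an unbranched chain ending in the same carboxylic acid would test. They also leave open whether the differences between these chains persist when a tetrazole stands in place of the carboxylic acid.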